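Aryl variation at the thiourea-linked imine of the shared core

This account rests on a few compounds, and the source may have more. Where it says the series, first, only, none or still open, it means among the compounds named here.

Measured compounds:
compound 1, `CC1=CC[C@@H]([C@@](C)(O)CCCC(C)(C)NC(=S)N/N=C\c2ccc(O)cc2)CC1` — in a functional assay on NCI/ADR cells (Homo sapiens) for cytotoxicity, read by sulforhodamine B assay (on this read-out higher numbers stand for weaker inhibition of growth and lower numbers for stronger inhibition of growth), compound 1 gives 8390 nM
compound 2, `CC1=CC[C@@H]([C@@](C)(O)CCCC(C)(C)NC(=S)N/N=C\c2ccccc2[N+](=O)[O-])CC1` — in this assay compound 2 gives 20400 nM

Compound 1 holds the lowest of the two numbers; the nearest, compound 2, lies a 2.4-fold higher number from compound 1 to compound 2 (0.39 log units; beyond the scatter). Compound 3, `CC1=CC[C@@H]([C@@](C)(O)CCCC(C)(C)NC(=S)N/N=C(/C)c2ccccc2)CC1`, differs from compound 1 by a group of 9 heavy atoms (8 carbon, 1 nitrogen; one six-membered aromatic ring of carbon only) in place of a group of 9 heavy atoms (7 carbon, 1 nitrogen, 1 oxygen; one six-membered aromatic ring of carbon only), on an amide-type nitrogen. For the measured compounds named here, the one measured step at this position, a 2.4-fold higher number from compound 1 to compound 2 (0.39 log units; beyond the scatter), also removed the 4-hydroxyphenyl and gave a modest rise. A rise of similar size is expected for compound 3, a 1.8-fold higher number from compound 1 to compound 3 (0.25 log units; within the scatter). The estimate for compound 3 in this assay is 15000 nM, within 6000 nM to 40000 nM.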

Compound 3, concentration for 50% growth inhibition: 750 nM
For compound 3 the middle estimate is 20-fold (1.30 log units) above the measured one, and the stated range ends above it.
By their numbers in this assay, from the lowest: compound 3; then compound 1; then compound 2.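

In this assay, the group on the amide-type nitrogen can lower the number as well as raise it: an 11-fold lower number from compound 1 to compound 3 (1.05 log units; beyond the scatter), against a 2.4-fold higher number from compound 1 to compound 2 (0.39 log units; beyond the scatter). Leaving the 4-hydroxyphenyl therefore sets no direction of its own, and the entering group decides the sign and size of the step, even at the same count of 9 heavy atoms. Nothing measured on these compounds accounts for the large drop.

Compound 3 changes the aryl substituent and the imine carbon at once, so their shares cannot be separated. As far as these compounds go, how an amine or a carboxylic acid in this group would read stays open.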